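Pyridyl amide exchange in the sulfamoyl urea series

The compounds below may be only part of what the source reports. "The series", "measured", "known", "first", "only" and "open" are said of these compounds alone.

The series shares a bicyclic urea sulfamide core with a piperidine-ethyl amide arm; the compounds differ only in the aryl group on the amide carbonyl. Compound 1 `O=C(NC[C@@H]1C[C@@H]2C=C[C@@H]1C2)NS(=O)(=O)N1CCC(CCNC(=O)c2cnsc2)CC1` carries a 1,2-thiazol-4-yl there, compound 2 `COc1ccc(C(=O)NCCC2CCN(S(=O)(=O)NC(=O)NC[C@@H]3C[C@@H]4C=C[C@@H]3C4)CC2)cn1` a 6-methoxypyridin-3-yl. In a functional assay on the whole organism (blood) with Rattus norvegicus as the target, with stated times of 24 h and 1 h, at a dose of 15 mg/kg by the intraperitoneal route (on this read-out lower numbers stand for a weaker effect and higher numbers for a stronger effect at the one dose given), compound 1 gives 14% and compound 2 gives 32%. For the measured compounds named here, the one step so far, a number 18 percentage points higher from compound 1 to compound 2 (beyond the scatter), is beyond the scatter, and compound 2 therefore stands highest of the two numbers.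

Compound 3 `O=C(NC[C@@H]1C[C@@H]2C=C[C@@H]1C2)NS(=O)(=O)N1CCC(CCNC(=O)c2cnccc2Cl)CC1` is the next member. Relative to compound 2 it differs in one place: 4-chloropyridin-3-yl in place of 6-methoxypyridin-3-yl on a carbonyl carbon

Going by the values given here, no measured step covers this exchange of one pyridyl group for another on the carbonyl carbon; the single step from the thiazolyl to the methoxypyridinyl shows that the aryl group on this carbonyl can move the read-out by a modest amount, in either direction. A change of moderate size, most likely downward from compound 2 since compound 2 is the upper of the two numbers, is expected. For compound 3 in this assay the estimate is 24%, within 8% to 45%, which is expected to mean a step of a number 8 percentage points lower from compound 2 to compound 3 (within the scatter).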

Compound 3, a percentage reported as activity, at one dose (the size of the read-out at that dose, not a potency): 12%
Beside the measured number, compound 3's estimate is 12 percentage points above it, within the range that was stated.
By their numbers in this assay, from the lowest: compounds 3 and 1 (each within the scatter of the next); then compound 2.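

In this assay, a move from one pyridyl group to another on the carbonyl carbon is enough to shift the read-out: a number 20 percentage points lower from compound 2 to compound 3 (beyond the scatter) is the step for 4-chloropyridin-3-yl in place of 6-methoxypyridin-3-yl. The higher number of compound 2 therefore does not go with the pyridine ring as such, but with this particular substituted pyridinyl group. With a number 2 percentage points lower from compound 1 to compound 3 (within the scatter) as the other step, the 4-chloropyridin-3-yl and 1,2-thiazol-4-yl amides cannot be told apart at this dose, so among the three aryl groups only 6-methoxypyridin-3-yl stands clear of the others. The data at hand offer no measurement that accounts for these differences.

The exchange changes both the substituent and its ring position at once, so the compounds shown cannot say which of the two matters. The unsubstituted pyridin-3-yl, 6-chloropyridin-3-yl and 4-methoxypyridin-3-yl amides would separate these two changes, and a 6-ethoxypyridin-3-yl or 6-aminopyridin-3-yl group would test how much the read-out depends on the methoxy group itself.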